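Methyl for chloro: expected inhibition of compound 3

This account rests on a few compounds, and the source may have more. Where it says the series, first, only, none or still open, it means among the compounds named here.

Measured compounds in an assay on cells for inhibition of S-adenosylmethionine decarboxylase proenzyme (Homo sapiens), read by mass spectrometry, at pH 7.2; on this read-out higher numbers stand for weaker inhibition and lower numbers for stronger inhibition:
compound 1 `CCc1cc(Br)cc(Nc2cc(C)nc(N)n2)c1`: > 180000 nM
compound 2 `Cc1cc(Nc2cc(Cl)c(Cl)c(Cl)c2)nc(N)n1`: > 63000 nM

Both readings in this assay are limits of the assay and not numbers. Compound 1 sits at the limit of > 180000 nM in this assay, at which 1 of the 2 values shown sits. Going by the values given here, compound 2 sits at the limit of > 63000 nM in this assay, at which 1 of the 2 values shown sits, so for compound 2 only a limit is known, and no measured compound has a numerical value.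

Compound 3 `Cc1cc(Nc2cc(Cl)c(C)c(Cl)c2)nc(N)n1` differs from compound 2 by methyl in place of chloro on an aromatic carbon. Among the compounds with values here, no step between measured compounds is available, so nothing measured tells how large an effect such a change has here. With compound 2 known only as a limit, the step is expected to be none beyond the scatter, estimated as a step that the limit leaves unreadable from compound 2 to compound 3. Compound 3 is therefore expected at 100000 nM, with a range from 30000 nM to 300000 nM, and most likely reported again as a limit.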

Compound 3, half-maximal inhibitory concentration: > 63000 nM
Compound 3 ended at the assay's limit; the forecaster's own chance of this, stated with the estimate: 80%; the middle value does not contradict the limit.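

In this assay compound 2 reads > 63000 nM, a limit. Going by these compounds alone, compound 3 reads > 63000 nM, again a limit, and no step between compound 2 and compound 3 can be read. The compounds shown leave open how far methyl in place of chloro shifts inhibition, and whether any compound in this series gives a numerical value in this assay.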